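Substituent swap on the pendant aryl ring of a shared core

This account rests on a few compounds, and the source may have more. Where it says the series, first, only, none or still open, it means among the compounds named here.

Measured so far:
compound 1, `Fc1ccc(C2CC(c3ccc(Cl)s3)=NN2c2nc(-c3ccc(C(F)(F)F)cc3)cs2)cc1`: > 500 ug/mL
compound 2, `Fc1ccc(C2CC(c3ccc(Cl)s3)=NN2c2nc(-c3ccc(Br)cc3)cs2)cc1`: 62.5 ug/mL
compound 3, `Cc1ccc(-c2csc(N3N=C(c4ccc(Cl)s4)CC3c3ccc(F)cc3)n2)cc1`: > 500 ug/mL

In a functional assay on A549 cells (Homo sapiens) for antiproliferative activity, read by XTT assay, with a stated time of 24 h (a lower number here means a stronger inhibitor, a higher number a weaker inhibitor), compound 3 gives only a limit, > 500 ug/mL. Compound 1 also sits at a limit, > 500 ug/mL. Among the compounds with values here, compound 2 is the one compound with a number, 62.5 ug/mL. Two of the three values sit at the limit (the limit of > 500 ug/mL in this assay, at which 2 of the 3 values shown sit), so the step that the two limits leave unreadable from compound 1 to compound 3 cannot be read, while an at least 8.0-fold higher number from compound 2 to compound 3 (0.90 log units; beyond the scatter) and an at least 8.0-fold lower number from compound 1 to compound 2 (0.90 log units; beyond the scatter) are readable.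

Compound 4, `Fc1ccc(-c2csc(N3N=C(c4ccc(Cl)s4)CC3c3ccc(F)cc3)n2)cc1`, differs from compound 3 by fluoro in place of methyl on an aromatic carbon. Within the data shown here, no measured step exchanges methyl for fluoro; the nearest is an at least 8.0-fold higher number from compound 2 to compound 3 (0.90 log units; beyond the scatter), where the other halogen of this set gave the only number. Compound 4 is therefore expected to give a number near the limit, estimated at 250 ug/mL (range 60 ug/mL to 500 ug/mL), a step of an at least 2.0-fold lower number from compound 3 to compound 4 (0.30 log units; that floor lies within the scatter) that is expected to stay small.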

Compound 4, half-maximal inhibitory concentration: > 500 ug/mL
Compound 4 was reported as a limit; the forecaster's own chance of this, stated with the estimate: 50%; middle value at least 2.0-fold (0.30 log units) away from the limit.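

Fluoro in place of bromo does not keep the activity of compound 2 in this assay, giving an at least 8.0-fold higher number from compound 2 to compound 4 (0.90 log units; beyond the scatter). A halogen at this place is therefore not enough on its own, and among the four groups shown, only bromo gives a number. The steps from compound 3 to compound 4 and from compound 1 to compound 4 cannot be read, because both ends of each sit at the limit: the limit of > 500 ug/mL in this assay, at which 3 of the 4 values shown sit.

As far as these compounds go, how chloro, iodo, methoxy, an amine or a carboxylic acid would read at this place stays open. So does any difference among compound 1, compound 3 and compound 4.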